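This account rests on a few compounds, and the source may have more. Where it says the series, first, only, none or still open, it means among the compounds named here.

Of the compounds shown here, three of one series have so far been tested in a functional assay on Molt4/C8 cells (Homo sapiens) for cytotoxicity; on this read-out lower numbers stand for stronger inhibition and higher numbers for weaker inhibition. Compound 1 `O=C(/C=C/C(=O)N1C/C(=C\c2ccccc2)C(=O)/C(=C/c2ccccc2)C1)Nc1ccc(Cl)c(Cl)c1` gives 1700 nM, the highest of the three numbers, though its gap to compound 2 lies within the scatter and only its gap to compound 3 lies beyond it. Compound 2 `O=C(/C=C/C(=O)N1C/C(=C\c2ccc([N+](=O)[O-])cc2)C(=O)/C(=C/c2ccc([N+](=O)[O-])cc2)C1)Nc1ccc(Cl)cc1` gives 1200 nM, and compound 3 `Cc1ccc(NC(=O)/C=C/C(=O)N2C/C(=C\c3ccc([N+](=O)[O-])cc3)C(=O)/C(=C/c3ccc([N+](=O)[O-])cc3)C2)cc1C` gives 660 nM. Compound 4 `COc1ccc(NC(=O)/C=C/C(=O)N2C/C(=C\c3ccccc3)C(=O)/C(=C/c3ccccc3)C2)cc1` is not yet measured; it differs from compound 1 by 4-methoxyphenyl in place of 3,4-dichlorophenyl on an amide-type nitrogen. Among the compounds with values here, one measured step touches the same position: a 1.8-fold lower number from compound 2 to compound 3 (0.26 log units; within the scatter). That step suggests little movement, so for compound 4 no step beyond the scatter is expected, and the expected change is a 1.1-fold lower number from compound 1 to compound 4 (0.05 log units; within the scatter). In this assay compound 4 is therefore estimated at 1500 nM, most likely between 600 nM and 3800 nM.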

Compound 4, half-maximal inhibitory concentration: 1100 nM
Compound 4: middle estimate off by 1.4-fold (0.13 log units), on the high side, and the stated range covers the measured number.
By their numbers in this assay, from the lowest: compounds 3, 4, 2 and 1 (each within the scatter of the next, the first and the last beyond it).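

In this assay, replacing 3,4-dichlorophenyl with 4-methoxyphenyl on the amide-type nitrogen gives a 1.5-fold lower number from compound 1 to compound 4 (0.19 log units; within the scatter). This is a second step at this position within the scatter, now on the core of compound 1, which lacks the nitro groups of compound 2 and compound 3. Swapping two chlorines for a methoxy group, which adds a hydrogen-bond acceptor, therefore leaves the number about level, and nothing available explains why. Still open, as far as these compounds go, is whether a carboxylic acid or an amine on this phenyl ring, or a longer chain in its place, would produce a step beyond the scatter.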